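The source may report more compounds than this note shows. Statements on the series, on what has been measured and on what is new or still open speak of the compounds shown alone.

Measured compounds:
- compound 1, `CCc1ccc(CN[C@@H]2C[C@H]3C[C@@H]([C@H]2C)C3(C)C)s1`, 1560 nM in an ADME assay on MDCK cells (Canis lupus familiaris) for cytotoxicity, read by microscopy, with a stated time of 48 h; a lower number here means that less compound is tolerated, a higher number that more compound is tolerated
- compound 2, `C[C@H]1[C@H](NCc2ccc(Cl)s2)C[C@H]2C[C@@H]1C2(C)C`, 25000 nM in this assay

Compound 2 stands at the highest of the two numbers in this assay, so more of it is tolerated by the cells than of compound 1. Within the data shown here, the single measured step runs from compound 1 to compound 2: a 16-fold higher number from compound 1 to compound 2 (1.20 log units; beyond the scatter).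

Compound 3, `C[C@H]1[C@H](NCc2ccc(-c3ccc(Br)s3)s2)C[C@H]2C[C@@H]1C2(C)C`, has not yet been measured. It differs from compound 2 in one place: 5-bromothiophen-2-yl in place of chloro on an aromatic carbon.

The step from compound 1 to compound 2 bears on this change, since it altered the same aromatic carbon of the same five-membered ring: chloro took the place of ethyl there and the number rose by a large amount. Now the chloro itself gives way to 5-bromothiophen-2-yl. Among the measured compounds shown here, no measured pair shows what such a ring for halogen swap does, so the direction is uncertain. Given the size of the only measured change at this position, a 16-fold higher number from compound 1 to compound 2 (1.20 log units; beyond the scatter), a sizeable step in either direction is plausible; the estimate for compound 3 is therefore placed somewhat below compound 2 and wide, a 3.1-fold lower number from compound 2 to compound 3 (0.49 log units; beyond the scatter). Compound 3 is expected to give about 8000 nM in this assay, with a range from 2000 nM to 30000 nM.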

Compound 3, minimum cytotoxic concentration: 780 nM
For compound 3 the middle estimate is 10-fold (1.01 log units) above the measured one; the whole stated range lies above it.
By their numbers in this assay, from the lowest: compounds 3 and 1 (each within the scatter of the next); then compound 2.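

Among these compounds, at the aromatic carbon next to the ring sulfur, chloro is so far the only group that goes with a high tolerated amount in this assay, since placing 5-bromothiophen-2-yl there gives a 32-fold lower number from compound 2 to compound 3 (1.51 log units; beyond the scatter), a large drop. This step is about as large as the earlier rise seen when chloro replaced ethyl, a 16-fold higher number from compound 1 to compound 2 (1.20 log units; beyond the scatter), so the high number of compound 2 does not come from the shared core alone and depends on what sits at this one carbon. Ethyl and 5-bromothiophen-2-yl are very different groups, one a small chain and the other a second aromatic ring, yet this assay does not tell them apart, with a 2.0-fold lower number from compound 1 to compound 3 (0.30 log units; within the scatter).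

No measurement at hand explains why chloro stands apart from the other two groups. On these data alone, it remains open whether a lone bromine or fluorine would behave like chloro, and whether a longer carbon chain, a plain phenyl ring or an amine at this carbon would join compound 1 and compound 3 or compound 2.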